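This account rests on a few compounds, and the source may have more. Where it says the series, first, only, none or still open, it means among the compounds named here.

Compound 1 `CC(C)N(CCN(C(=O)Nc1cccc(Br)c1)C1CC[C@]2(c3cccc(C#N)c3)CC2C1)C(C)C`: in a functional assay for antagonist activity at melanin-concentrating hormone receptor 1 (Homo sapiens) (a higher number here means a weaker inhibitor, a lower number a stronger inhibitor), compound 1 gives 5.7 nM.
Compound 2 `CC(C)N(CCN(C(=O)Nc1cccc(F)c1)C1CC[C@]2(c3cccc(C#N)c3)CC2C1)C(C)C`: in this assay compound 2 gives 2.1 nM.
Compound 3 `CC(C)N(CCN(C(=O)Nc1cc(F)cc(F)c1)C1CC[C@]2(c3cccc(C#N)c3)CC2C1)C(C)C`: in this assay compound 3 gives 4.5 nM.

All three share one core and differ only in the aromatic group carried on the amide-type nitrogen. Compound 3 stands second highest of the three numbers. Its nearest neighbour is compound 1: a 1.3-fold lower number from compound 1 to compound 3 (0.10 log units; within the scatter). Further off is compound 2: a 2.1-fold higher number from compound 2 to compound 3 (0.33 log units; beyond the scatter).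

Compound 4 `CC(C)N(CCN(C(=O)Nc1ccc(F)c(F)c1)C1CC[C@]2(c3cccc(C#N)c3)CC2C1)C(C)C` differs from compound 3 by 3,4-difluorophenyl in place of 3,5-difluorophenyl on an amide-type nitrogen; the same atoms are present, only the second fluorine sits on a different ring carbon. Every change seen so far on this ring has moved the number only modestly: swapping bromine for fluorine gave a 2.7-fold lower number from compound 1 to compound 2 (0.43 log units; beyond the scatter), adding a second fluorine gave a 2.1-fold higher number from compound 2 to compound 3 (0.33 log units; beyond the scatter), and replacing the 3-bromophenyl by the 3,5-difluorophenyl gave a 1.3-fold lower number from compound 1 to compound 3 (0.10 log units; within the scatter). Shifting one fluorine within the ring is a change of the same kind and size, so no step beyond the scatter is expected in this assay, in either direction. Compound 4 is therefore estimated at 3.5 nM, within 1.5 nM to 8 nM, which means an expected step of a 1.3-fold lower number from compound 3 to compound 4 (0.11 log units; within the scatter).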

Compound 4, inhibition constant: 2.8 nM
Estimate against measurement, compound 4: 1.3-fold (0.10 log units) above; low and high end bracket the measured number.
By their numbers in this assay, from the lowest: compounds 2, 4, 3 and 1 (each within the scatter of the next, the first and the last beyond it).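

Moving one fluorine, from the 3,5-difluorophenyl to the 3,4-difluorophenyl group on the amide-type nitrogen, gives no step beyond the scatter in this assay (a 1.6-fold lower number from compound 3 to compound 4 (0.21 log units; within the scatter)), so this site accepts that rearrangement of the ring without a readable change. The two difluorophenyl groups do differ in one comparison: adding a second fluorine to the 3-fluorophenyl compound to give the 3,4-difluorophenyl group stays within the scatter (a 1.3-fold higher number from compound 2 to compound 4 (0.12 log units; within the scatter)), whereas adding it to give the 3,5-difluorophenyl group lies just beyond it (a 2.1-fold higher number from compound 2 to compound 3 (0.33 log units; beyond the scatter)), and the 3,4-difluorophenyl group also gives a lower number than the 3-bromophenyl group (a 2.0-fold lower number from compound 1 to compound 4 (0.31 log units; beyond the scatter)). Nothing at hand explains these small differences.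

Going by these compounds, all four compounds carry fluorine or bromine on this ring, so it remains open how a methoxy group, an amine or a carboxylic acid in those places would behave. On these data alone, how a 4-fluorophenyl group with its single fluorine, or a plain phenyl group, would compare also remains open.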